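Pyrazole nitrogen substituent change in an HCC78 series

This account rests on a few compounds, and the source may have more. Where it says the series, first, only, none or still open, it means among the compounds named here.

Measured compounds:
- compound 1 `COc1ccc(CNC(=O)c2cccc(C(C)Oc3ccnc(Nc4cnn(C)c4)c3)c2)cc1OC`: 76600 nM
- compound 2 `COc1cc(CNC(=O)c2cccc(C(C)Oc3ccnc(Nc4cnn(C)c4)c3)c2)cc(OC)c1OC`: 73900 nM
- compound 3 `Cc1ccc(CNC(=O)c2cccc(C(C)Oc3ccnc(Nc4cnn(C)c4)c3)c2)cc1`: 8900 nM

In a functional assay on HCC78 cells (Homo sapiens) for antiproliferative activity, read by MTT assay, with a stated time of 48 h (a lower number here means a stronger inhibitor, a higher number a weaker inhibitor), compound 1 gives 76600 nM, the highest of the three numbers; compound 2 sits within the scatter of it, a 1.0-fold lower number from compound 1 to compound 2 (0.02 log units; within the scatter). Going by the values given here, compound 3 is the only measured compound set apart, with an 8.6-fold lower number from compound 1 to compound 3 (0.93 log units; beyond the scatter) and an 8.3-fold lower number from compound 2 to compound 3 (0.92 log units; beyond the scatter), both changes on the saturated chain carbon bound to the amide-type nitrogen.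

Compound 4 `COc1ccc(CNC(=O)c2cccc(C(C)Oc3ccnc(Nc4cnn(C5CCN(C)CC5)c4)c3)c2)cc1OC` differs from compound 1 elsewhere: 1-methylpiperidin-4-yl in place of methyl on an aromatic nitrogen. Among the compounds with values here, none of the measured steps touches this aromatic nitrogen, so no measured step bears on the change directly. Within the data shown here, the only steps known to move this assay beyond the scatter concern the benzylic aryl group, which is identical in compound 1 and compound 4. Without a comparable precedent, no step beyond the scatter is expected, and the uncertainty is wide.

Compound 4 is therefore estimated at 70000 nM, with a range of 20000 nM to 200000 nM, which means an expected step of a 1.1-fold lower number from compound 1 to compound 4 (0.04 log units; within the scatter).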

Compound 4, half-maximal inhibitory concentration: 9000 nM
Beside the measured number, compound 4's estimate is 7.8-fold (0.89 log units) above it; the measured number lies below the stated range.
By their numbers in this assay, from the lowest: compounds 3 and 4 (each within the scatter of the next); then compounds 2 and 1 (each within the scatter of the next).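

In this assay the aromatic nitrogen of the five-membered aromatic ring proves to be a second place that moves the number: 1-methylpiperidin-4-yl in place of methyl gives an 8.5-fold lower number from compound 1 to compound 4 (0.93 log units; beyond the scatter) with the 3,4-dimethoxyphenyl group unchanged. Until now, only changes to the aryl group on the saturated chain carbon had gone beyond the scatter. This position therefore takes a group of 7 heavy atoms, including a six-membered non-aromatic ring, with a lower number rather than a higher one, but nothing at hand accounts for the step.

On these data alone, whether the ring or its nitrogen carries the step remains open; a cyclohexyl group or an unsubstituted piperidin-4-yl group at this nitrogen would separate the two. Also open, as far as these compounds go, is whether 1-methylpiperidin-4-yl and 4-methylphenyl add up when both stand on one molecule.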